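The source may hold more compounds than are shown below. What is called first, only, known or untested is meant among the compounds shown, and "the series" means these compounds.

Compound 1 `CC(=O)SCCC(CCCCC(=O)Nc1ccccc1)SC(C)=O` gives 3.2% in a functional assay on HO8910 cells (Homo sapiens) for inhibition, read by MTT assay, with a stated time of 24 h, tested at 10 ug/mL; a lower number here means less inhibition of growth, a higher number more inhibition of growth at the concentration tested. In this assay, for the measured compounds named here, compound 2 `CC(=O)SCCC(CCCCC(=O)Nc1ccccc1Cl)SC(C)=O` has no single number: compound 2 is reported as "not active" (no number reported), so no numerical step from compound 1 can be stated. Compound 3 `CC(=O)SCCC(CCCCC(=O)Nc1cccc(Cl)c1)SC(C)=O` differs from compound 2 as follows: 3-chlorophenyl in place of 2-chlorophenyl on an amide-type nitrogen. This places 3-chlorophenyl in place of 2-chlorophenyl on an amide-type nitrogen. Going by the values given here, the series holds no measured step for such a change, so no step beyond the scatter is expected in this assay, and growth inhibition is expected to remain low. For compound 3 the estimated value is 5%, with an expected range of 0% to 18%.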

Compound 3, percent growth inhibition at one concentration: "not active" (no number reported)
No number was reported for compound 3; no gap can be computed for the estimate.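

In this assay compound 2 and compound 3 are both reported as not active, so no step can be read between them. The compounds shown leave open how far either chlorophenyl group shifts growth inhibition from compound 1. No measured evidence bears on this result.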